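A few compounds are considered here, and "the series" means these few. Any claim that something is new, unique, unknown or untested is made for them only; others in the source may bear on it.

Measured in a functional assay on MGC-803 cells (Homo sapiens) for cytotoxicity, read by MTT assay, with a stated time of 48 h; a higher number here means a weaker inhibitor, a lower number a stronger inhibitor:

compound 1 `CCC(=O)N1N=C(C)CC1c1cc(Br)ccc1O`: 50300 nM
compound 2 `CCC(=O)N1N=C(C)CC1c1cc(Br)cc(Br)c1O`: 38600 nM
compound 3 `CC1=NN(S(=O)(=O)c2ccc([N+](=O)[O-])cc2)C(c2cc(Br)cc(Br)c2O)C1`: 40100 nM

Compound 1 lies within the usual scatter of both other compounds, so these three values cannot be ranked. The next compound to be tested is compound 4 `C=CCN(CC=C)CC(=O)N1N=C(C)CC1c1cc(Br)ccc1O`. Its difference from compound 1 is diallylamino in place of methyl on a saturated chain carbon bound to a carbonyl carbon. In words, this is diallylamino in place of methyl on a saturated chain carbon bound to a carbonyl carbon.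

For the measured compounds named here, only one measured step connects two compounds that differ in a single place: a 1.3-fold lower number from compound 1 to compound 2 (0.11 log units; within the scatter). That change puts bromo in place of hydrogen on an aromatic carbon, and the step stays within the scatter. It offers only weak guidance, since it happens elsewhere on the molecule and involves a different kind of group. Going by the values given here, no measured step shows what a change on the chain does, and the new group is much larger than the methyl it replaces. Among the compounds with values here, the data therefore support no confident direction in this assay, and no step clearly beyond the scatter is expected. The expected step is a 1.4-fold lower number from compound 1 to compound 4 (0.16 log units; within the scatter), with real uncertainty on either side. For compound 4 the estimated value is 35000 nM, with an expected range from 12000 nM to 90000 nM.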

Compound 4, half-maximal inhibitory concentration: 10200 nM
For compound 4 the middle estimate is 3.4-fold (0.54 log units) above the measured one, outside the stated range (below it).
By their numbers in this assay, from the lowest: compound 4; then compounds 2, 3 and 1 (each within the scatter of the next).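

The chain carbon bound to the carbonyl carbon proves to be a place where a change can register: in this assay, putting diallylamino in place of methyl gives a 4.9-fold lower number from compound 1 to compound 4 (0.69 log units; beyond the scatter). For the compounds shown here, the earlier bromo step on an aromatic carbon stayed within the scatter, so this is the first single change to move the number clearly, and it makes compound 4 the stronger inhibitor of the pair even though the entering group has 7 heavy atoms against the 1 of the methyl it replaces. No supporting measurement is available to explain why this change lowers the number.

This single example cannot separate the contribution of the nitrogen from that of the two allyl arms and their double bonds; a dimethylamino group, a morpholine or a plain butyl chain at the same place would begin to pull these apart. Going by these compounds, it also remains open whether diallylamino would lower the number to a similar extent on the core of compound 2, which carries a further bromo.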